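A few compounds are considered here, and "the series" means these few. Any claim that something is new, unique, unknown or untested is made for them only; others in the source may bear on it.

Three compounds built on one shared core have been compared in a functional assay on KG-1 cells (Homo sapiens) for antiproliferative activity; on this read-out lower numbers stand for an effect already at smaller amounts and higher numbers for an effect only at larger amounts of compound. Compound 1 `NC(=O)c1cc(Cl)c2c(Cl)c(C#CC3CCOCC3)n([C@H]3CCCNC3)c2n1` gives 69 nM. Compound 2 `CC(O)C#Cc1c(Cl)c2c(Cl)cc(C(N)=O)nc2n1[C@H]1CCCNC1` gives 147 nM, and compound 3 `CC1(CC#Cc2c(Cl)c3c(Cl)cc(C(N)=O)nc3n2[C@H]2CCCNC2)COC1` gives 289 nM. Compound 3 therefore carries the highest of the three numbers, though its gap to compound 2 is within the scatter, whereas its gap to compound 1 is beyond it. The single-point steps that connect these compounds read a 2.1-fold higher number from compound 1 to compound 2 (0.33 log units; beyond the scatter), a 4.2-fold higher number from compound 1 to compound 3 (0.62 log units; beyond the scatter) and a 2.0-fold higher number from compound 2 to compound 3 (0.29 log units; within the scatter); all of them exchange the group on the triple-bonded carbon.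

Compound 4 `COC(C)(C)CC#Cc1c(Cl)c2c(Cl)cc(C(N)=O)nc2n1[C@H]1CCCNC1` differs from compound 3 at one place: 1-methoxy-1-methylethyl in place of 3-methyloxetan-3-yl on a saturated chain carbon bound to a triple-bonded carbon. Among the measured compounds shown here, none of the measured steps exchanges one such saturated ether-bearing group for another, so the guidance is indirect. The two measured changes that most resemble it, a 2.0-fold higher number from compound 2 to compound 3 (0.29 log units; within the scatter) and a 4.2-fold higher number from compound 1 to compound 3 (0.62 log units; beyond the scatter), are one within and one beyond the scatter, the larger one arising where a ring on the triple-bonded carbon was replaced by a chain. For compound 4 a step that stays close to the scatter, a 1.1-fold lower number from compound 3 to compound 4 (0.05 log units; within the scatter), is expected in this assay. Compound 4 is accordingly estimated at 260 nM in this assay, with a likely range from 110 nM to 620 nM.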

Compound 4, half-maximal effective concentration: 172 nM
Beside the measured number, compound 4's estimate is 1.5-fold (0.18 log units) above it, within the range that was stated.
By their numbers in this assay, from the lowest: compound 1; then compounds 2, 4 and 3 (each within the scatter of the next).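

In this assay, replacing the four-membered ring of 3-methyloxetan-3-yl with the open 1-methoxy-1-methylethyl, which has the same count of heavy atoms and one hydrogen-bond acceptor as well, gives a 1.7-fold lower number from compound 3 to compound 4 (0.23 log units; within the scatter), so on a saturated chain carbon bound to a triple-bonded carbon this pair shows no need for the ring. Compared directly on the triple-bonded carbon, 2-methoxy-2-methylpropyl and 1-hydroxyethyl give a 1.2-fold higher number from compound 2 to compound 4 (0.07 log units; within the scatter), which means that an ether-bearing chain with no hydrogen-bond donor and a shorter hydroxyl-bearing group cannot be told apart here. The step from oxan-4-yl gives a 2.5-fold higher number from compound 1 to compound 4 (0.40 log units; beyond the scatter), so compound 1 now stands apart from all three chain-bearing compounds by steps beyond the scatter.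

No evidence at hand accounts for any of these differences. Going by these compounds, it stays open whether the result for compound 1 depends on the ring oxygen of oxan-4-yl, as a cyclohexyl group would show, and how a piperidin-4-yl amine, a carboxylic acid or a longer chain on the triple-bonded carbon would read out in this assay.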